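A Larger Group Replaces Piperidin-4-yl

A few compounds are considered here, and "the series" means these few. Any claim that something is new, unique, unknown or untested is made for them only; others in the source may bear on it.

In a functional assay on MKN-45 cells (Homo sapiens) for antiproliferative activity, read by CellTiter-Glo, with a stated time of 3 days (a higher number here means a weaker inhibitor, a lower number a stronger inhibitor), compound 3 (`C[C@@H](Oc1c(N)ncc2c(C3CCNCC3)coc12)c1c(Cl)ccc(F)c1Cl`) gives 3100 nM, compound 1 (`CC(Oc1c(N)ncc2c(-c3cnn(C4CCNCC4)c3)coc12)c1c(Cl)cc(Cl)cc1Cl`) gives 3600 nM and compound 2 (`C[C@@H](Oc1c(N)ncc2c(-c3ccccn3)coc12)c1c(Cl)ccc(F)c1Cl`) gives 4600 nM, so all three sit within the usual scatter of one another. Compound 4 (`COC(=O)N1CC=C(c2coc3c(O[C@H](C)c4c(Cl)ccc(F)c4Cl)c(N)ncc23)CC1`) keeps the core of compound 3 but changes one group on an aromatic carbon: a group of 10 heavy atoms (7 carbon, 1 nitrogen, 2 oxygen; one six-membered non-aromatic ring with 1 hetero atom) in place of a group of 6 heavy atoms (5 carbon, 1 nitrogen; one six-membered non-aromatic ring with 1 hetero atom), on an aromatic carbon. Within the data shown here, the one measured step that bears on this is a 1.5-fold lower number from compound 2 to compound 3 (0.17 log units; within the scatter), where piperidin-4-yl took the place of pyridin-2-yl. Among the measured compounds shown here, that step stays within the scatter, so no step beyond the scatter is expected in this assay, although no measured compound carries the entering group. The estimated change is a 1.1-fold higher number from compound 3 to compound 4 (0.05 log units; within the scatter). For compound 4 the expected value is 3500 nM, with an estimated range of 1500 nM to 8000 nM.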

Compound 4, half-maximal inhibitory concentration: 850 nM
Estimate against measurement, compound 4: 4.1-fold (0.61 log units) above; measured number outside the range, below it.
By their numbers in this assay, from the lowest: compound 4; then compounds 3, 1 and 2 (each within the scatter of the next).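

In this assay the group on this aromatic carbon can shift the number after all: the larger group gives a 3.6-fold lower number from compound 3 to compound 4 (0.56 log units; beyond the scatter) and a 5.4-fold lower number from compound 2 to compound 4 (0.73 log units; beyond the scatter) and both steps lie beyond the scatter, unlike the earlier exchange of pyridin-2-yl for piperidin-4-yl. The position is therefore not indifferent to what sits there. Nothing measured here explains the change.

Two features change together, the double bond in the six-membered ring and the group on its nitrogen, so the compounds shown do not separate them. As far as these compounds go, a plain methyl or a longer chain on that nitrogen remains open.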